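A few compounds are considered here, and "the series" means these few. Any claim that something is new, unique, unknown or untested is made for them only; others in the source may bear on it.

Measured so far in a physicochemical assay for solubility, read by HPLC, with a stated time of 24 h (a lower number here means a less soluble compound, a higher number a more soluble compound), for three compounds:
- compound 1 `CC(C)(C)c1[nH]cnc1/C=c1\[nH]c(=O)/c(=C/c2cccc(C(=O)N3CCC3)c2)[nH]c1=O`: 4.23 ug/mL
- compound 2 `CC(C)(C)c1[nH]cnc1/C=c1\[nH]c(=O)/c(=C/c2cccc(C(=O)N3CCCCC3)c2)[nH]c1=O`: < 0.1 ug/mL (a limit)
- compound 3 `CC(C)(C)c1[nH]cnc1/C=c1\[nH]c(=O)/c(=C/c2cccc(C(=O)c3cccnc3)c2)[nH]c1=O`: < 0.1 ug/mL (a limit)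

Compound 3 holds only a limit (see (the limit of < 0.1 ug/mL in this assay, at which 2 of the 3 values shown sit)) and so gives no exact starting number. Compound 4 `CC(C)(C)c1[nH]cnc1/C=c1\[nH]c(=O)/c(=C/c2cccc(C(=O)c3ccncc3)c2)[nH]c1=O` carries pyridin-4-yl in place of pyridin-3-yl on a carbonyl carbon with the same atoms joined differently. The nearest measured steps both replace azetidin-1-yl on a carbonyl carbon. Both an at least 42-fold lower number from compound 1 to compound 2 (1.62 log units; beyond the scatter) and an at least 42-fold lower number from compound 1 to compound 3 (1.62 log units; beyond the scatter) are large, while a step that the two limits leave unreadable from compound 2 to compound 3 stays unreadable. Within the data shown here, no measured step exchanges one pyridinyl group for another, so no step beyond the scatter is expected in this assay here. The expected step is a step that the limit leaves unreadable from compound 3 to compound 4 by this estimate. Compound 4 is estimated at 0.08 ug/mL (expected range 0.03 ug/mL to 0.4 ug/mL).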

Compound 4, solubility: < 0.1 ug/mL
Compound 4: only a limit was reported (the forecaster's own chance of this, stated with the estimate: 75%); the middle value does not contradict the limit.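

In this assay, compound 4, with pyridin-4-yl on the carbonyl carbon, holds only a limit, < 0.1 ug/mL. Its comparison with the azetidin-1-yl amide reads an at least 42-fold lower number from compound 1 to compound 4 (1.62 log units; beyond the scatter), so the second pyridinyl placement also leaves the value at the limit, which now holds most of the series: the limit of < 0.1 ug/mL in this assay, at which 3 of the 4 values shown sit. The steps among compound 2, compound 3 and compound 4 cannot be read, as each joins two limits.

Any real difference between pyridin-3-yl and pyridin-4-yl stays open. Also open, as far as these compounds go, is whether pyrrolidin-1-yl or morpholin-4-yl on the carbonyl carbon would give an exact value in this assay.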